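Aryl urea swap: trifluoromethyl to chloro in a quinoline series

The source may hold more compounds than are shown below. What is called first, only, known or untested is meant among the compounds shown, and "the series" means these compounds.

Compound 1 `COc1cc2cc(Oc3ccc(NC(=O)Nc4cccc(C(F)(F)F)c4)cc3)c(C)nc2cc1OC`: 1600 nM
Compound 2 `COc1cc2cc(Oc3ccc(NC(=O)Nc4ccc(Cl)c(C(F)(F)F)c4)cc3)c(C)nc2cc1OC`: 1070 nM

In a functional assay on NCI-H460 cells (Homo sapiens) for inhibition, read by sulforhodamine B assay, with a stated time of 48 h (on this read-out lower numbers stand for stronger inhibition of growth and higher numbers for weaker inhibition of growth), compound 2 stands with the lowest number of the two, but the step of a 1.5-fold lower number from compound 1 to compound 2 (0.17 log units; within the scatter) lies within the scatter, so the two values cannot be ordered. Compound 3 `COc1cc2cc(Oc3ccc(NC(=O)Nc4ccc(Cl)c(Cl)c4)cc3)c(C)nc2cc1OC` differs from compound 2 by chloro in place of trifluoromethyl on an aromatic carbon. For the measured compounds named here, no measured step exchanges trifluoromethyl for chloro; the one step known, a 1.5-fold lower number from compound 1 to compound 2 (0.17 log units; within the scatter), adds chloro and changes little. Compound 3 is therefore expected to give 1300 nM, between 500 nM and 3500 nM, an expected step of a 1.2-fold higher number from compound 2 to compound 3 (0.08 log units; within the scatter), not beyond the scatter.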

Compound 3, concentration for 50% growth inhibition: 2460 nM
For compound 3 the middle estimate is 1.9-fold (0.28 log units) below the measured one; the measured number falls inside the stated range.
By their numbers in this assay, from the lowest: compounds 2, 1 and 3 (each within the scatter of the next, the first and the last beyond it).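

In this assay, for the compounds shown here, exchanging trifluoromethyl for chloro on the aromatic carbon ortho to a chloro group gives a 2.3-fold higher number from compound 2 to compound 3 (0.36 log units; beyond the scatter) as the first step beyond the scatter, so the group held here can alter growth inhibition, if only modestly. With a 1.5-fold higher number from compound 1 to compound 3 (0.19 log units; within the scatter) inside the scatter, however, 3,4-dichlorophenyl and 3-(trifluoromethyl)phenyl cannot be ordered. Nothing given here explains the step. On these data alone, whether an amine or a carboxylic acid at this position would move the number further remains open.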